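Phthalimidomethyl anilides as mGlu5 modulators: amide variation

A few compounds are considered here, and "the series" means these few. Any claim that something is new, unique, unknown or untested is made for them only; others in the source may bear on it.

Measured so far in an assay on CHO cells for positive allosteric modulation of metabotropic glutamate receptor 5 (Rattus norvegicus), read by FLIPR; a lower number here means that less compound is needed, a higher number that more compound is needed for the effect:
Compound 1 `O=C(Nc1ccc(Cl)cc1CN1C(=O)c2ccccc2C1=O)c1ccccc1`: compound 1 gives < 1000 nM, a limit of the assay.
Compound 2 `O=C(Nc1ccc(Cl)cc1CN1C(=O)c2ccccc2C1=O)c1ccco1`: compound 2 gives < 1000 nM, also a limit.
Compound 3 `O=C(Nc1ccc(Cl)cc1CN1C(=O)c2ccccc2C1=O)C1CCCCC1`: compound 3 gives < 1000 nM, again a limit.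

Compound 1 thus stands only at a limit in this assay, and the two further values are limits too (the limit of < 1000 nM in this assay, at which 3 of the 3 values shown sit). The steps a step that the two limits leave unreadable from compound 1 to compound 2, a step that the two limits leave unreadable from compound 1 to compound 3 and a step that the two limits leave unreadable from compound 2 to compound 3 are all unreadable; they say nothing about how much the group on the carbonyl carbon matters within the range below the limit.

Compound 4 `O=C(Nc1ccc(Cl)cc1CN1C(=O)c2ccccc2C1=O)c1cncs1` differs from compound 1 by 1,3-thiazol-5-yl in place of phenyl on a carbonyl carbon. Three carbonyl substituents, an aromatic ring, a five-membered aromatic ring with one hetero atom and a saturated ring, all stay under the limit, so the change to 1,3-thiazol-5-yl is expected to keep compound 4 under it as well; no step beyond the scatter is readable from the data, and a step that the limit leaves unreadable from compound 1 to compound 4 is the estimated step. Compound 4 is expected at 300 nM, within 30 nM to 1500 nM.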

Compound 4, half-maximal effective concentration: < 1000 nM
Compound 4: a limit, no number (the forecaster's own chance of this, stated with the estimate: 65%); the middle value is on the limit's open side.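

In this assay compound 4 gives < 1000 nM as a limit, not a number. No step from compound 4 to compound 1, compound 2 or compound 3 can be read: the limit of < 1000 nM in this assay, at which 4 of the 4 values shown sit.

The compounds shown leave open how far apart these four lie under the limit.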